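The source may report more compounds than this note shows. Statements on the series, on what has been measured and on what is new or still open speak of the compounds shown alone.

In an ADME assay on NIH3T3 cells (Mus musculus) for cytotoxicity (on this read-out lower numbers stand for higher toxicity in this test and higher numbers for lower toxicity in this test), compound 1 `CN1CCN(CC#Cc2cc3ncnc(Nc4ccc(OCc5cccc(F)c5)c(Cl)c4)c3s2)CC1` gives 4.8 uM and compound 2 `CCOC(=O)CN(C)CC#Cc1cc2ncnc(Nc3ccc(OCc4cccc(F)c4)c(Cl)c3)c2s1` gives 52 uM, so compound 2 holds the higher of the two numbers. Compound 3 `CC(C)(C)CC#Cc1cc2ncnc(Nc3ccc(OCc4cccc(F)c4)c(Cl)c3)c2s1` keeps the shared core and alters one group: tert-butyl in place of ((ethoxycarbonyl)methyl)(methyl)amino on a saturated chain carbon bound to a triple-bonded carbon. Here tert-butyl stands in place of ((ethoxycarbonyl)methyl)(methyl)amino on a saturated chain carbon bound to a triple-bonded carbon. Among the measured compounds shown here, only one measured step bears on this change, since it altered the same place: an 11-fold higher number from compound 1 to compound 2 (1.03 log units; beyond the scatter). That large step, beyond the scatter, shows that this assay can respond strongly to the group here. For the measured compounds named here, no measured compound carries tert-butyl, however, so the step gives no firm direction. With compound 2 at the top of this short range, a moderate move toward a lower number is expected, smaller than that step. The expected change is a 2.4-fold lower number from compound 2 to compound 3 (0.37 log units; beyond the scatter). The estimate for compound 3 is 22 uM, with an expected range from 7 uM to 70 uM.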

Compound 3, half-maximal toxic concentration: > 50 uM
Compound 3 ended at the assay's limit; the forecaster's own chance of this, stated with the estimate: 15%; middle value at least 2.2-fold (0.35 log units) from the limit.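

In this assay compound 3 gives > 50 uM, which is a limit of the assay and not a number. Replacing 4-methylpiperazin-1-yl with tert-butyl, which has no hydrogen-bond acceptors, is a large change, an at least 10-fold higher number from compound 1 to compound 3 (1.01 log units; beyond the scatter), so a high number at this place does not depend on the ((ethoxycarbonyl)methyl)(methyl)amino group of compound 2. The step between compound 2 and compound 3 cannot be read, so the two groups cannot be ranked, because compound 3 sits at the ceiling of the test: the limit of > 50 uM in this assay, at which 1 of the 3 values shown sits.

The compounds shown leave open whether the low number of compound 1 goes with its piperazine ring or with its amine nitrogens. A morpholine or a plain dimethylamino group at this place would help to separate the two, and a carboxylic acid in place of the ethyl ester would test that part of compound 2.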